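The source may hold more compounds than are shown below. What is called first, only, known or untested is meant among the compounds shown, and "the series" means these compounds.

Four compounds share one core and differ only in the group carried on a saturated chain carbon bound to an amine nitrogen in a ring. Going by the values given here, compound 1 `N#Cc1ccccc1CN1CCC(O)(Cn2cnc3c(cnn3-c3ccc(F)cc3)c2=O)CC1` is the one with a number: in an assay on Sf21 cells for inhibition of ubiquitin carboxyl-terminal hydrolase 7 (Homo sapiens), read by spectrophotometry, with stated times of 30 min and 2 h (on this read-out higher numbers stand for weaker inhibition and lower numbers for stronger inhibition), compound 1 gives 8100 nM. Compound 2 `N#Cc1ccc(CN2CCC(O)(Cn3cnc4c(cnn4-c4ccc(F)cc4)c3=O)CC2)cc1` and compound 3 `O=c1c2cnn(-c3ccc(F)cc3)c2ncn1CC1(O)CCN(Cc2ccc(C(F)(F)F)cc2)CC1` were also tested in this assay, but for neither was a single number reported: in this assay compound 2 is recorded as "not determined" (no result reported), and in this assay compound 3 is recorded as "not determined" (no result reported), so compound 2 stands without a value, and compound 3 is the one further entry in the same position. Compound 4 `N#Cc1cc(Cl)ccc1CN1CCC(O)(Cn2cnc3c(cnn3-c3ccc(F)cc3)c2=O)CC1` has not yet been measured in this assay.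

The change from compound 2 to compound 4 is 4-chloro-2-cyanophenyl in place of 4-cyanophenyl on a saturated chain carbon bound to an amine nitrogen in a ring. Among the compounds with values here, with no number for compound 2, the size and direction of this step in this assay cannot be set against its starting point; the only anchor is compound 1, and a step from compound 1 to compound 4 is not one that has been measured, so no step beyond the scatter can be claimed in either direction. On that footing, compound 4 is expected in this assay to give about 5000 nM, estimated to fall between 1500 nM and 20000 nM.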

Compound 4, half-maximal inhibitory concentration: 11400 nM
Compound 4: the middle estimate sits 2.3-fold (0.36 log units) below what was measured, and the stated range covers the measured number.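

The step from 4-cyanophenyl to 4-chloro-2-cyanophenyl cannot be read, as compound 2 has no number in this assay. Going by these compounds alone, the one comparison available at this position is chloro in place of hydrogen on an aromatic carbon, and it gives a 1.4-fold higher number from compound 1 to compound 4 (0.15 log units; within the scatter), so in this assay the two compounds cannot be told apart. No measurement at hand offers a reason for this result.

The compounds shown leave open how a group other than chloro, such as a methoxy or an amine, would read on this same ring in this assay. Within the data shown here, they also leave open whether any change on this benzyl group can move the number beyond the scatter, as only one step here can be read.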